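The source may hold more compounds than are shown below. What is called first, only, known or untested is meant among the compounds shown, and "the series" means these compounds.

Compound 1 `O=C1COc2ccc(-c3cnc(Cl)c(NS(=O)(=O)c4ccc(F)cc4)c3)cc2N1C1CCCCC1`, compound 2 `COc1ncc(-c2ccc3c(c2)N(C2CCCCC2)C(=O)CO3)cc1NS(=O)(=O)c1ccc(F)cc1` and compound 3 `O=C1COc2ccc(-c3cccc(NS(=O)(=O)c4ccc(F)cc4)c3)cc2N1c1ccc(F)cc1` share one core and the same sulfonamide arm. In a functional assay on HepG2 cells (Homo sapiens) for antiproliferative activity, read by MTT assay, with a stated time of 72 h (on this read-out higher numbers stand for weaker inhibition and lower numbers for stronger inhibition), compound 1 gives only the limit > 40000 nM. In this assay compound 2 likewise gives only the limit > 40000 nM, so compound 2 stands at a limit and not at a number. Compound 3 gives only the limit > 40000 nM in this assay. The step that the two limits leave unreadable from compound 1 to compound 2 is unreadable, since both ends sit at the limit of > 40000 nM in this assay, at which 3 of the 3 values shown sit. Compound 4 `COc1ncc(-c2ccc3c(c2)N(c2ccccc2)C(=O)CO3)cc1NS(=O)(=O)c1ccc(F)cc1` differs from compound 2 by phenyl in place of cyclohexyl on an amide-type nitrogen in a ring. Going by the values given here, no measured step covers this change; compound 3, which also carries an aromatic ring on the amide nitrogen, shows only a limit. The step that the limit leaves unreadable from compound 2 to compound 4 is therefore expected to remain unreadable. Compound 4 is estimated at 60000 nM, between 15000 nM and 200000 nM.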

Compound 4, half-maximal inhibitory concentration: 14000 nM
Estimate against measurement, compound 4: 4.3-fold (0.63 log units) above; measured number outside the range, below it.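

In this assay, going by these compounds alone, the amide-type nitrogen in the ring is the first place where a change gives a readable step: phenyl in place of cyclohexyl gives an at least 2.8-fold lower number from compound 2 to compound 4 (0.45 log units; beyond the scatter). Compound 4 holds the only number shown so far. The size of this step remains a lower bound, since compound 2 stands at a limit and not at a number: the limit of > 40000 nM in this assay, at which 3 of the 4 values shown sit.

Still open, as far as these compounds go, is whether other groups on this nitrogen, such as benzyl, a pyridine ring or a chain ending in an amine, would lower the number further. From the compounds shown here alone, it is also open whether phenyl gives a similar step with chloro in place of methoxy.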